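The source may hold more compounds than are shown below. What is called first, only, known or untested is meant among the compounds shown, and "the series" means these compounds.

Three compounds with a shared core were tested in an assay on isolated protein for binding affinity to leukotriene B4 receptor 1 (Homo sapiens), tested at 1 uM; a lower number here means less inhibition, a higher number more inhibition at the concentration tested (going by the name of the read-out). Compound 1, `CC(=O)c1cc(C(C)=O)c(OCCCCC#N)cc1O`, gives 0% in this assay. Compound 2, `C=CCc1cc(C(C)=O)c(O)cc1OCC#N`, gives 2%. Compound 3, `CCc1cc(C(C)=O)c(O)cc1OCCCCC(C)(C)C#N`, gives 30%. Among these three numbers compound 2 stands second highest. Its nearest neighbour is compound 1, whose number lies within the usual scatter of that of compound 2, so the two cannot be told apart. The furthest is compound 3, whose number lies well beyond the scatter above that of compound 2.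

The unmeasured compound 4, `C=CCc1cc(C(C)=O)c(O)cc1OCCCC`, differs from compound 2 in one place: propyl in place of cyano on a saturated chain carbon bound to an oxygen on an aromatic ring. Among the compounds with values here, no pair of measured compounds shows this change by itself, so its size cannot be read from a measured step. Compound 3 carries a longer chain and a nitrile on it and gives the highest number, but it differs from compound 2 in more than one place and does not isolate the change.

An estimate for compound 4 of 8% in this assay, between 0% and 30%, is expected. The step of a number 6 percentage points higher from compound 2 to compound 4 (within the scatter) is expected to be small and to stay within the scatter, with the upper end of the range allowing for a rise toward the number of compound 3.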

Compound 4, a percentage reported as inhibition, at one concentration (the size of the read-out at that concentration, not a potency): 8%
Estimate against measurement, compound 4: no gap at the digits printed; measured number inside the range.
By their numbers in this assay, from the lowest: compounds 1, 2 and 4 (each within the scatter of the next); then compound 3.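

In this assay, within the data shown here, the exchange of cyano for propyl, on a saturated chain carbon bound to an oxygen on an aromatic ring, gives a number 6 percentage points higher from compound 2 to compound 4 (within the scatter), the first step in this set that isolates a single change at one place. It shows that, on the shared core of compound 2, the cyanomethoxy group and the butoxy group cannot be told apart by their numbers, so the nitrile and the longer chain ending in propyl read alike at this place, and both numbers stay low at the concentration tested. No measurement shown here gives any account of this result.

What the compounds shown leave open is whether an amine or a carboxylic acid at the end of this chain, or a chain longer than butyl, would give a number beyond the scatter of those of compound 2 and compound 4 on the same core. Also open, from the compounds shown here alone, is whether the same exchange of cyano for propyl would read alike on the core of compound 3, whose number stands well clear of theirs.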